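The source may hold more compounds than are shown below. What is called first, only, known or untested is meant among the compounds shown, and "the series" means these compounds.

Notes on the series. Compound 2 `O=C(C1CCOCC1)N1CCc2nc(C#Cc3ccccc3)sc2C1` gives 290 nM in an assay on HEK293 cells for positive allosteric modulation of metabotropic glutamate receptor 5 (Homo sapiens), read by FLIPR, with a stated time of 1 h (a lower number here means that less compound is needed, a higher number that more compound is needed for the effect), the lowest of the two numbers seen so far; its nearest neighbour is compound 1 `COC1CC(C(=O)N2CCc3nc(C#Cc4ccccc4)sc3C2)C1`, which gives 640 nM in this assay, with a 2.2-fold lower number from compound 1 to compound 2 (0.34 log units; beyond the scatter) between them. Compound 3 `O=S(=O)(C1CC1)N1CCc2nc(C#Cc3ccccc3)sc2C1` is not yet measured; it differs from compound 2 by cyclopropylsulfonyl in place of (oxan-4-yl)carbonyl on an amine nitrogen in a ring. Among the measured compounds shown here, the only measured step, the exchange of the ring on the carbonyl carbon from compound 1 to compound 2, was modest and does not touch the carbonyl itself; no measured pair shows a carbonyl exchanged for a sulfonyl on this nitrogen, so the direction of the step is not fixed by the data. Given this, a change of uncertain direction with wide bounds is expected, a 2.1-fold higher number from compound 2 to compound 3 (0.32 log units; beyond the scatter). For compound 3 a value near 600 nM in this assay is estimated, within a range from 150 nM to 2500 nM.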

Compound 3, half-maximal effective concentration: > 10000 nM
Compound 3 was reported as a limit; the forecaster's own chance of this, stated with the estimate: 10%; at least 16-fold (1.22 log units) between middle value and limit.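

Compound 3 is reported only as a limit of the assay, not as a number: the limit of > 10000 nM in this assay, at which 1 of the 3 values shown sits. Until now this amine nitrogen in a ring had shown only a modest change, with the ring on the carbonyl carbon exchanged, whereas cyclopropylsulfonyl on the same nitrogen gives an at least 34-fold higher number from compound 2 to compound 3 (1.53 log units; beyond the scatter) and an at least 15-fold higher number from compound 1 to compound 3 (1.19 log units; beyond the scatter). In this assay, the position therefore accepts an exchange of the ring on the carbonyl carbon with a far smaller step than the exchange of either whole carbonyl group for cyclopropylsulfonyl.

The link and the ring change together in these steps, so the compounds shown do not separate the share of the sulfonyl from that of the cyclopropyl ring. A cyclopropylcarbonyl group or an oxan-4-ylsulfonyl group on this nitrogen would divide the step into those two parts.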